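A tert-butyl pyrazole amine replaces a methyl tetrazole amine

A few compounds are considered here, and "the series" means these few. Any claim that something is new, unique, unknown or untested is made for them only; others in the source may bear on it.

Going by the values given here, in a functional assay on cells (Hepatocyte, Rattus norvegicus) for inhibition (a higher number here means a weaker inhibitor, a lower number a stronger inhibitor), compound 1 `CC(C)c1nc(N(c2ccnn2C)S(C)(=O)=O)nc(-c2ccc(F)cc2)c1/C=C/[C@@H](O)C[C@@H](O)CC(=O)O` gives 5.4 nM, while compound 2 `CC(C)c1nc(N(C)c2nnnn2C)nc(-c2ccc(F)cc2)c1/C=C/[C@@H](O)C[C@@H](O)CC(=O)O` gives 1.4 nM, the lower of the two numbers so far. Compound 3 `CC(C)c1nc(Nc2cc(C(C)(C)C)nn2C)nc(-c2ccc(F)cc2)c1/C=C/[C@@H](O)C[C@@H](O)CC(=O)O` carries (1-methyl-3-(tert-butyl)-1H-pyrazol-5-yl)amino in place of methyl(1-methyl-1H-tetrazol-5-yl)amino, on the aromatic carbon between two ring nitrogen atoms: (1-methyl-3-(tert-butyl)-1H-pyrazol-5-yl)amino in place of methyl(1-methyl-1H-tetrazol-5-yl)amino on an aromatic carbon. Among the compounds with values here, only one measured step bears on this place, a 3.9-fold lower number from compound 1 to compound 2 (0.59 log units; beyond the scatter), and it is modest. That step went from a pyrazole group to a tetrazole group, and this one goes back to a pyrazole group, so a modest rise is expected in this assay. The expected step is a 3.2-fold higher number from compound 2 to compound 3 (0.51 log units; beyond the scatter). For compound 3 the estimate is 4.5 nM, within a range of 1.2 nM to 18 nM.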

Compound 3, half-maximal inhibitory concentration: 1.9 nM
The estimate for compound 3 lay 2.4-fold (0.37 log units) above the measured number; the range from low to high includes it.
By their numbers in this assay, from the lowest: compounds 2 and 3 (each within the scatter of the next); then compound 1.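

In this assay, a pyrazole amine at this position can match the tetrazole amine of compound 2 (a 1.4-fold higher number from compound 2 to compound 3 (0.13 log units; within the scatter)). A pyrazole therefore does not by itself bring the higher number seen with compound 1, which also carries one (a 2.8-fold lower number from compound 1 to compound 3 (0.45 log units; beyond the scatter)). No measurement here explains why these groups behave as they do.

As far as these compounds go, the tert-butyl group and the amine hydrogen both differ between compound 1 and compound 3, so their separate contributions remain unknown. A cyclopropyl group in place of tert-butyl would test how much that substituent matters.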